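Iodo for isopropyl on the aryl sulfonate of compound 2

The compounds below may be only part of what the source reports. "The series", "measured", "known", "first", "only" and "open" are said of these compounds alone.

Measured compounds:
- compound 1, `CC(=O)Nc1ccc(S(=O)(=O)Oc2ccccc2I)cc1`: 23000 nM
- compound 2, `CCCCCNC(=O)Nc1ccc(S(=O)(=O)Oc2ccccc2C(C)C)cc1`: 4900 nM

In a functional assay on HT-29 cells (Homo sapiens) for antiproliferative activity, read by sulforhodamine B assay, with a stated time of 48 h (a lower number here means a stronger inhibitor, a higher number a weaker inhibitor), compound 2 gives 4900 nM, the lower of the two numbers; compound 1 gives 23000 nM, a gap beyond the scatter. Compound 1 and compound 2 differ in two places at once, so their two values say nothing about either change on its own.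

Compound 3, `CCCCCNC(=O)Nc1ccc(S(=O)(=O)Oc2ccccc2I)cc1`, has not been measured in this assay. It keeps the pentylurea of compound 2 and changes the aryl sulfonate: iodo in place of isopropyl on an aromatic carbon. Nothing in the measured pairs isolates this exchange. Both groups lack donors and acceptors and both sit on an aromatic carbon ortho to a large group, so the expected step from compound 2 to compound 3 is a 1.4-fold higher number from compound 2 to compound 3 (0.15 log units; within the scatter), not beyond the scatter. For compound 3 the estimated value in this assay is 7000 nM, with a range from 2500 nM to 20000 nM.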

Compound 3, half-maximal inhibitory concentration: 6600 nM
For compound 3 the middle estimate is 1.1-fold (0.03 log units) above the measured one, within the range that was stated.
By their numbers in this assay, from the lowest: compounds 2 and 3 (each within the scatter of the next); then compound 1.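

In this assay, iodo in place of isopropyl on the aromatic carbon gives a 1.3-fold higher number from compound 2 to compound 3 (0.13 log units; within the scatter), so with the pentylurea held fixed, the compounds shown do not separate these two groups at this position. Compound 3 also isolates the other change: with the 2-iodophenyl kept, pentylamino in place of methyl on a carbonyl carbon gives a 3.5-fold lower number from compound 1 to compound 3 (0.54 log units; beyond the scatter), which the pair of compound 1 and compound 2 could not show on its own. No measurement shown explains either step.

On these data alone, whether an amine or a carboxylic acid on the same aromatic carbon would give a step beyond the scatter remains open. So does whether a butylamino or hexylamino group on the carbonyl carbon would extend or reverse the step seen with pentylamino.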